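A few compounds are considered here, and "the series" means these few. Any claim that something is new, unique, unknown or untested is made for them only; others in the source may bear on it.

Measured compounds in a functional assay on HCT-116 cells (Homo sapiens) for antiproliferative activity, read by MTT assay, with a stated time of 72 h; a lower number here means a stronger inhibitor of growth, a higher number a weaker inhibitor of growth:
Compound 1 `Cc1ccc(Nc2nc3ncccc3n2Cc2ccccc2)cc1[N+](=O)[O-]`: 40400 nM
Compound 2 `Cn1nc(-c2ccnc(Nc3ccc(O)cc3)n2)c2ccccc21`: 8430 nM
Compound 3 `Cn1nc(-c2ccnc(Nc3cccc(O)c3)n2)c2ccccc21`: 17200 nM

Compound 2 has the lowest number of the three. Its nearest neighbour is compound 3, reached by a 2.0-fold higher number from compound 2 to compound 3 (0.31 log units; beyond the scatter); compound 1, built on a different core, lies furthest away from compound 2 in this assay. Compound 4 `Cn1nc(-c2ccnc(Nc3ccc([N+](=O)[O-])cc3)n2)c2ccccc21` shares the core of compound 2 and differs from it in one place: nitro in place of hydroxy on an aromatic carbon. Going by the values given here, none of the measured steps bears directly on this exchange; the single step, from compound 2 to compound 3, moves the hydroxy group between positions and keeps the group itself, so it says nothing about a nitro group in the same place. Compound 1 carries a nitro group, but on another core and at another position, so its value alone cannot be read across. Among the compounds with values here, with no step to lean on, compound 4 is expected to stay in the range of the measured compounds, the step of a 1.8-fold higher number from compound 2 to compound 4 (0.25 log units; within the scatter) being estimated as a modest loss or none beyond the scatter. Compound 4 is therefore expected to give about 15000 nM, within 5000 nM to 50000 nM.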

Compound 4, concentration for 50% growth inhibition: 8220 nM
Compound 4: the middle estimate sits 1.8-fold (0.26 log units) above what was measured; measured number inside the range.
By their numbers in this assay, from the lowest: compounds 4 and 2 (each within the scatter of the next); then compound 3; then compound 1.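

In this assay, nitro in place of hydroxy on an aromatic carbon, para to a large group, gives a 1.0-fold lower number from compound 2 to compound 4 (0.01 log units; within the scatter), so compound 2 and compound 4 cannot be told apart. On this core, then, the hydrogen-bond donor of the hydroxy group is not needed at this position to hold the number, and the larger nitro group, which has no such donor, is accepted there, whereas the only other step shown, which moves the hydroxy group, gives a 2.0-fold higher number from compound 2 to compound 3 (0.31 log units; beyond the scatter). Nothing measured here accounts for this result.

As far as these compounds go, it remains open whether an amine or a carboxylic acid at the same place would also stay level with compound 2 and compound 4. From the compounds shown here alone, it is also open how a nitro group would behave at the place the hydroxy group occupies in compound 3.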